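Swapping a benzothiophene for a dimethylphenyl group

A few compounds are considered here, and "the series" means these few. Any claim that something is new, unique, unknown or untested is made for them only; others in the source may bear on it.

Compound 1 `O=C(O)CC1COc2cc(OCc3cccc(-c4csc5ccccc45)c3)ccc21`: in an assay on CHO cells for displacement of a labelled ligand from Free fatty acid receptor 1 (Rattus norvegicus), read by scintillation counting, with a stated time of 90 min, in the presence of a further agent that is not named here (a lower number here means a stronger inhibitor, a higher number a weaker inhibitor), compound 1 gives > 10000 nM, which is a limit of the assay and not a number.
Compound 2 `O=C(O)CC1COc2cc(OCc3cccc(-c4ccc5sccc5c4)c3)ccc21`: in this assay compound 2 gives > 10000 nM, again a limit.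
Compound 3 `COc1ccc(COc2ccc3c(c2)OCC3CC(=O)O)cc1-c1c(C)cccc1C`: in this assay compound 3 gives 1600 nM.

Compound 2 thus stands at the limit of > 10000 nM in this assay, at which 2 of the 3 values shown sit, alongside compound 1. The step that the two limits leave unreadable from compound 1 to compound 2 is unreadable, since both its ends are limits. Compound 4 `Cc1ccc(-c2cccc(COc3ccc4c(c3)OCC4CC(=O)O)c2)c(C)c1` differs from compound 2 by 2,4-dimethylphenyl in place of 1-benzothiophen-5-yl on an aromatic carbon. Going by the values given here, no measured step covers this exact change. Compound 3, which carries a different dimethylphenyl group, does give a number, so compound 4 is expected to move off the limit, and its step from compound 2 is estimated as an at least 4.0-fold lower number from compound 2 to compound 4 (0.60 log units; beyond the scatter). For compound 4 the expected value is 2500 nM, with a range from 600 nM to 10000 nM.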

Compound 4, inhibition constant: 1600 nM
For compound 4 the middle estimate is 1.6-fold (0.19 log units) above the measured one, within the range that was stated.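

Placing 2,4-dimethylphenyl on this aromatic carbon brings a benzothiophene compound off the limit, with an at least 6.2-fold lower number from compound 2 to compound 4 (0.79 log units; beyond the scatter) and an at least 6.2-fold lower number from compound 1 to compound 4 (0.79 log units; beyond the scatter). Both steps are open-ended, since each starts from a limit: the limit of > 10000 nM in this assay, at which 2 of the 4 values shown sit.

At this position, then, a single six-membered aromatic ring carrying two methyl groups gives a readable value in this assay, which neither benzothiophene attachment does. Open, from the compounds shown here alone, is whether the methyl groups matter at all, or whether a plain phenyl or a pyridyl group on the same carbon would give a comparable value.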